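The source may hold more compounds than are shown below. What is called first, only, known or untested is meant among the compounds shown, and "the series" means these compounds.

Working notes on the series. Going by the values given here, the three measured members share one core. Compound 1 `O=[N+]([O-])c1cccc(C2=Nn3c(nnc3-c3ccncc3)SC2)c1` carries a nitrophenyl group on that core and, in an assay on isolated protein for inhibition of Intestinal-type alkaline phosphatase (Bos taurus), with stated times of 10 min and 30 min (on this read-out lower numbers stand for stronger inhibition and higher numbers for weaker inhibition), compound 1 gives 3590 nM. Compound 2 `Fc1ccc(OCc2nn3c(-c4ccncc4)nnc3s2)cc1` and compound 3 `Oc1ccc(OCc2nn3c(-c4ccncc4)nnc3s2)cc1` instead link a substituted phenoxymethyl group to the core; in this assay compound 2 gives 2590 nM and compound 3 gives 5610 nM. Among the compounds with values here, compound 3 has the highest of the three numbers, although its gap to compound 1 lies within the scatter, while the one single-point step in the set, a 2.2-fold higher number from compound 2 to compound 3 (0.34 log units; beyond the scatter), is beyond the scatter but still modest.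

Compound 4 `COc1ccc(OCc2nn3c(-c4ccncc4)nnc3s2)cc1` is the next member: methyl in place of hydrogen on an oxygen on an aromatic ring. Within the data shown here, no measured step covers this change, so only the weight of the neighbouring data can guide the expectation. Compounds 2 and 3 show that altering the substituent on the distal phenyl ring moves this read-out only modestly, and compound 1 sits close to compound 3 as well. On that basis the step from compound 3 to compound 4 is expected to be small, a 1.5-fold lower number from compound 3 to compound 4 (0.17 log units; within the scatter), with no firm direction to claim. The estimate for compound 4 in this assay is 3800 nM, within a range from 1600 nM to 9000 nM, to be checked against the actual measurement.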

Compound 4, half-maximal inhibitory concentration: 3720 nM
Beside the measured number, compound 4's estimate is 1.0-fold (0.01 log units) above it, within the range that was stated.
By their numbers in this assay, from the lowest: compounds 2, 1, 4 and 3 (each within the scatter of the next, the first and the last beyond it).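

Methyl on this oxygen leaves the number within the scatter, with this assay reading a 1.5-fold lower number from compound 3 to compound 4 (0.18 log units; within the scatter) for the change from 4-hydroxyphenyl to 4-methoxyphenyl, so the hydrogen on this oxygen is not shown to matter for the read-out. The methoxy member also stays within the scatter of the fluoro member, at a 1.4-fold higher number from compound 2 to compound 4 (0.16 log units; within the scatter) in this comparison, which leaves a 2.2-fold higher number from compound 2 to compound 3 (0.34 log units; beyond the scatter) as the only one of the three steps among these substituents that lies beyond the scatter, and that step remains modest. No available evidence bears on the reason for these numbers.

Still open, on these data alone, is whether an ethoxy group or a longer chain on this oxygen, or an amine or a carboxylic acid in place of the methoxy group, would stay within the same narrow band of values. Also open, as far as these compounds go, is whether a change on the shared core, rather than on the phenyl ring, would produce a larger step than any seen here.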